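This account rests on a few compounds, and the source may have more. Where it says the series, first, only, none or still open, it means among the compounds named here.

Values in a functional assay on MDA-MB-453 cells (Homo sapiens) for antiproliferative activity, read by MTT assay, with a stated time of 72 h (on this read-out lower numbers stand for stronger inhibition and higher numbers for weaker inhibition), for the series:

Compound 1 `CCOC(=O)c1c[nH]nc1N/C=C1\C(=O)NN=C1c1ccccc1` gives 74600 nM
Compound 2 `O=C1NN=C(c2ccccc2)/C1=C/Nc1cc(-c2ccco2)[nH]n1` gives 20900 nM
Compound 3 `O=C1/C(=C\Nc2cc(-c3ccco3)[nH]n2)C(c2ccccc2)=NN1c1ccccc1` gives 12400 nM

Compound 3 stands level with compound 2 within the scatter, a 1.7-fold lower number from compound 2 to compound 3 (0.23 log units; within the scatter), and its number lies clearly under that of compound 1.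

Compound 4 `O=C(O)[C@H](CO)N/C=C1\C(=O)N(c2ccccc2)N=C1c1ccccc1` carries 1-carboxy-2-hydroxyethyl in place of 5-(furan-2-yl)-1H-pyrazol-3-yl on an amine nitrogen of compound 3. The change counts as 1-carboxy-2-hydroxyethyl in place of 5-(furan-2-yl)-1H-pyrazol-3-yl on an amine nitrogen.

For the measured compounds named here, the one measured step, a 1.7-fold lower number from compound 2 to compound 3 (0.23 log units; within the scatter), concerns an amide-type nitrogen and does not touch this place. The group on the amine nitrogen does differ between compound 2 at 20900 nM and compound 1 at 74600 nM, and these two values lie further apart than that step. Going by the values given here, no measured compound has a group without a ring on this nitrogen, so the estimate is loose. A move towards a higher number in this assay is expected, beyond the scatter, as a 4.0-fold higher number from compound 3 to compound 4 (0.61 log units; beyond the scatter). For compound 4 the estimated value is 50000 nM, with an expected range from 15000 nM to 160000 nM.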

Compound 4, half-maximal inhibitory concentration: 49000 nM
Compound 4: the middle estimate sits 1.0-fold (0.01 log units) above what was measured; measured number inside the range.
By their numbers in this assay, from the lowest: compounds 3 and 2 (each within the scatter of the next); then compounds 4 and 1 (each within the scatter of the next).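

In this assay, for the compounds shown here, replacing 5-(furan-2-yl)-1H-pyrazol-3-yl with 1-carboxy-2-hydroxyethyl on the amine nitrogen gives a 4.0-fold higher number from compound 3 to compound 4 (0.60 log units; beyond the scatter), the first measured step at this place and one with no ring in the entering group. This position therefore responds to its substituent beyond the scatter, whereas the phenyl change on the amide-type nitrogen, a 1.7-fold lower number from compound 2 to compound 3 (0.23 log units; within the scatter), stays within it. No measurement shown here offers an explanation for the step.

As far as these compounds go, the change removes both aromatic rings and brings in the carboxy and hydroxy groups at once, so the share of each in the step remains open. A benzyl group or a plain ethyl chain on the amine nitrogen would help to separate these two contributions.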